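Series notes: pyrrolidine to pyridinyl-piperazine on the shared core

The compounds below may be only part of what the source reports. "The series", "measured", "known", "first", "only" and "open" are said of these compounds alone.

Compound 1 `COc1ccc(NC(=O)Nc2nc(Sc3c[nH]c4ccccc34)cc(N3CCN(c4ccccn4)CC3)n2)cc1` gives 11400 nM in a functional assay on HepG2 cells (Homo sapiens) for inhibition, with a stated time of 72 h; on this read-out higher numbers stand for weaker inhibition and lower numbers for stronger inhibition. Compound 2 `O=C(Nc1ccccc1)Nc1nc(Sc2c[nH]c3ccccc23)cc(N2CCN(c3ccccn3)CC2)n1` gives 8930 nM, and the step of a 1.3-fold lower number from compound 1 to compound 2 (0.11 log units; within the scatter) lies within the scatter. Compound 3 `Cc1cc(Cl)ccc1NC(=O)Nc1nc(Sc2c[nH]c3ccccc23)cc(N2CCCC2)n1` gives 7150 nM, the low end of the three numbers, though its gaps to compound 2 and compound 1 both fall within the scatter. Compound 4 `Cc1cc(Cl)ccc1NC(=O)Nc1nc(Sc2c[nH]c3ccccc23)cc(N2CCN(c3ccccn3)CC2)n1` carries 4-(pyridin-2-yl)piperazin-1-yl in place of pyrrolidin-1-yl on an aromatic carbon. For the measured compounds named here, no measured step bears on this exchange; the only step recorded, from compound 1 to compound 2, concerns the aryl urea and stays within the scatter. The shared core and the indolylsulfanyl group remain, so compound 4 is expected to stay near compound 3, with the step of a 1.1-fold higher number from compound 3 to compound 4 (0.05 log units; within the scatter) estimated as none beyond the scatter. Compound 4 is therefore estimated at 8000 nM, within 3000 nM to 25000 nM.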

Compound 4, half-maximal inhibitory concentration: 7640 nM
Estimate against measurement, compound 4: 1.0-fold (0.02 log units) above; low and high end bracket the measured number.
By their numbers in this assay, from the lowest: compounds 3, 4, 2 and 1 (each within the scatter of the next).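

In this assay, 4-(pyridin-2-yl)piperazin-1-yl in place of pyrrolidin-1-yl on this aromatic carbon, next to the ring nitrogen, stays within the scatter (a 1.1-fold higher number from compound 3 to compound 4 (0.03 log units; within the scatter)), so the position accepts 12 heavy atoms as readily as 5. With the piperazine fixed, 4-chloro-2-methylphenyl on the urea also stays within the scatter, whether it replaces phenyl (a 1.2-fold lower number from compound 2 to compound 4 (0.07 log units; within the scatter)) or 4-methoxyphenyl (a 1.5-fold lower number from compound 1 to compound 4 (0.17 log units; within the scatter)). No supporting data bear on these results.

Open, on these data alone, is whether a primary amine or a carboxylic acid at this position would move the number beyond the scatter. As far as these compounds go, replacing the (1H-indol-3-yl)sulfanyl group also remains untested in these compounds.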